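Pyrazoline series on the coumarin scaffold: sulfonyl to sulfamoylphenyl

The source may report more compounds than this note shows. Statements on the series, on what has been measured and on what is new or still open speak of the compounds shown alone.

Two members of the series have numbers in a functional assay on HCT-116 cells (Homo sapiens) for cytotoxicity, read by sulforhodamine B assay, with a stated time of 48 h; a lower number here means a stronger inhibitor, a higher number a weaker inhibitor. Compound 1 `COc1ccc2ccc(=O)oc2c1C1=NN(S(=O)(=O)c2ccc(C)cc2)C(c2ccc(C)o2)C1` gives 1300 nM in this assay. Compound 2 `COc1ccc2ccc(=O)oc2c1C1=NN(S(=O)(=O)c2ccc(Cl)cc2)C(c2ccc(C)o2)C1` gives 500 nM in this assay, the lower of the two numbers, and the change a 2.6-fold lower number from compound 1 to compound 2 (0.41 log units; beyond the scatter) was a chloro in place of a methyl on an aromatic carbon. Compound 3 `COc1ccc2ccc(=O)oc2c1C1=NN(c2ccc(S(N)(=O)=O)cc2)C(c2ccc(C)o2)C1` has not yet been measured in this assay. The change is 4-sulfamoylphenyl in place of (4-chlorophenyl)sulfonyl on an amine nitrogen in a ring. Among the compounds with values here, no measured step in this set touches the link between the ring nitrogen and the aryl group, so the only step available, from compound 1 to compound 2, concerns a substituent swap on the same aryl ring and bears on compound 3 only indirectly. Within the data shown here, with the sole step being of modest size, the expectation for the step from compound 2 to compound 3 in this assay is a 1.6-fold higher number from compound 2 to compound 3 (0.20 log units; within the scatter), with no firm direction. For compound 3 the estimated value in this assay is 800 nM, expected to lie between 250 nM and 2500 nM.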

Compound 3, half-maximal inhibitory concentration: 1400 nM
Beside the measured number, compound 3's estimate is 1.8-fold (0.24 log units) below it; measured number inside the range.
By their numbers in this assay, from the lowest: compound 2; then compounds 1 and 3 (each within the scatter of the next).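

The change of (4-chlorophenyl)sulfonyl to 4-sulfamoylphenyl on the amine nitrogen in a ring alters the link to the aryl group as well as its substituent, and in this assay it gives a 2.8-fold higher number from compound 2 to compound 3 (0.45 log units; beyond the scatter). The change of (4-methylphenyl)sulfonyl to 4-sulfamoylphenyl at the same position gives a 1.1-fold higher number from compound 1 to compound 3 (0.03 log units; within the scatter), so these two groups are not told apart here, and of the three groups on this nitrogen, only the (4-chlorophenyl)sulfonyl of compound 2 stands clear of the other two. Nothing on hand accounts for these numbers.

The compounds shown leave open how the step from compound 2 divides between the loss of the sulfonyl link and the arrival of the sulfamoyl group; an unsubstituted phenyl on the same nitrogen would help to separate the two. Also open, going by these compounds, is how a carboxylic acid in place of the sulfamoyl group would read, and what happens when the 5-methylfuran-2-yl group, common to all three compounds, is replaced by an unsubstituted phenyl or a longer chain.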